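The source may report more compounds than this note shows. Statements on the series, on what has been measured and on what is new or still open speak of the compounds shown alone.

Measured compounds:
compound 1, `Cc1ccc(C(=O)N2N=C(c3ccc(N4CCN(C)CC4)cc3)CC2c2ccc(N(C)C)cc2)cc1`: -2.5%
compound 2, `CN1CCN(c2ccc(C3=NN(C(=O)c4ccc(C(F)(F)F)cc4)C(c4ccc(N(C)C)cc4)C3)cc2)CC1`: 84.1%

For the measured compounds named here, in a functional assay on HCC1806 cells (Homo sapiens) for inhibition, read by sulforhodamine B assay, tested at 10 uM (a lower number here means less inhibition, a higher number more inhibition at the concentration tested (going by the name of the read-out)), compound 1 gives -2.5%, the lowest of the two numbers known; its nearest neighbour is compound 2, which in this assay gives 84.1%. The two differ in one place, and the step of a number 86.6 percentage points higher from compound 1 to compound 2 (beyond the scatter) is large and well beyond the scatter.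

Compound 3, `CN1CCN(c2ccc(C3=NN(S(=O)(=O)c4ccc(C#N)cc4)C(c4ccc(N(C)C)cc4)C3)cc2)CC1`, has not yet been measured in this assay. It differs from compound 1 in the group on the amine nitrogen in the ring: (4-cyanophenyl)sulfonyl in place of (4-methylphenyl)carbonyl on an amine nitrogen in a ring. Going by the values given here, no measured pair shows this exact change. Among the compounds with values here, the only step that bears on it is the one from compound 1 to compound 2, which shows that a change of the group attached to the carbonyl on that ring nitrogen can move the read-out by a very large amount. Compound 3 changes the same part of the molecule, but both the attachment and the ring substituent are altered, so the direction rests on one step alone. Compound 3 is therefore expected to show a rise, a number 47.5 percentage points higher from compound 1 to compound 3 (beyond the scatter), with a wide margin. The estimate for compound 3 in this assay is 45%, within 0% to 90%.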

Compound 3, a percentage reported as inhibition, at one concentration (the size of the read-out at that concentration, not a potency): 99.8%
Compound 3: the middle estimate sits 54.8 percentage points below what was measured; the measured number lies above the stated range.
By their numbers in this assay, from the lowest: compound 1; then compound 2; then compound 3.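

On the amine nitrogen in the ring, the carbonyl link is not needed for a high read-out in this assay: (4-cyanophenyl)sulfonyl in place of (4-methylphenyl)carbonyl gives a number 102.3 percentage points higher from compound 1 to compound 3 (beyond the scatter). The earlier pair showed only a change on the aromatic ring with the carbonyl kept, whereas this change replaces the link as well and still reaches the top of the three numbers. Compound 3 also goes past the trifluoromethyl compound, with (4-cyanophenyl)sulfonyl in place of (4-(trifluoromethyl)phenyl)carbonyl giving a number 15.7 percentage points higher from compound 2 to compound 3 (beyond the scatter), a modest step beside the large one from the methyl compound, and nothing available here explains either step.

The sulfonyl and the nitrile enter together in compound 3, so the compounds shown do not tell how much of the rise belongs to each, and a sulfonyl carrying a plain methylphenyl ring or a carbonyl carrying a cyanophenyl ring would be needed to divide it. They also leave open whether an amine or a carboxylic acid in place of the nitrile would keep the read-out this high.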